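This account rests on a few compounds, and the source may have more. Where it says the series, first, only, none or still open, it means among the compounds named here.

Compound 2 `O=C(N1CCCCC1)C1(c2ccccc2)CCCC1` was examined in an ADME assay on MDCK cells (Canis lupus familiaris) for cytotoxicity; a higher number here means that more compound is tolerated, a lower number that less compound is tolerated. In this assay compound 2 reaches only a limit of the assay, giving > 100000 nM. Compound 1 `CC1(C)C[C@H](O)C[C@](C)(CNC(=O)c2cc(Cl)ccc2O)C1` likewise stops at a limit, giving > 50000 nM in this assay. Within the data shown here, of the two values shown, one sits at the limit of > 100000 nM in this assay, at which 1 of the 2 values shown sits, and one at the limit of > 50000 nM in this assay, at which 1 of the 2 values shown sits, so no step between measured compounds is counted. Compound 3 `O=C(N1CCOCC1)C1(c2ccccc2)CCCC1` carries morpholin-4-yl in place of piperidin-1-yl on a carbonyl carbon. For the step of a number no higher from compound 2 to compound 3 (the limit leaves the size open) the account expects no shift beyond the usual scatter. Compound 3 is therefore expected to give 100000 nM, somewhere between 50000 nM and 200000 nM, most likely again reported only as a limit.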

Compound 3, half-maximal cytotoxic concentration: > 100000 nM
Compound 3 gave a limit, no number; the forecaster's own chance of this, stated with the estimate: 80%; the middle value sits exactly at the limit.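

Compound 2 and compound 3 both end at a limit in this assay, so no step can be read between them. The compounds shown leave open whether morpholin-4-yl and piperidin-1-yl differ in this read-out at all.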